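A few compounds are considered here, and "the series" means these few. Any claim that something is new, unique, unknown or untested is made for them only; others in the source may bear on it.

Compound 2 `CCc1ccc2oc(N3CCN(C)CC3)nc2c1` stands at a limit: in a functional assay on ileum (strain Hartley) for agonist activity at 5-hydroxytryptamine receptor 3A (Cavia porcellus) (a lower number here means a less potent compound, a higher number a more potent compound, by a factor of ten per unit of this negative logarithm), compound 2 gives < 4, which is a limit of the assay and not a number. Compound 1 `COc1ccc2oc(N3CCN(C)CC3)nc2c1` gives 4.78 in this assay. For the measured compounds named here, the only measured step is a number at least 0.78 log units lower from compound 1 to compound 2 (beyond the scatter), which ends at the limit of < 4 in this assay, at which 1 of the 2 values shown sits. Compound 3 `CN1CCN(c2nc3cc(C(C)(C)C)ccc3o2)CC1` carries the change (tert-butyl in place of ethyl on an aromatic carbon), a further growth of the alkyl on that aromatic carbon. With compound 2 already at the limit, no step beyond the scatter is expected for a step that the limit leaves unreadable from compound 2 to compound 3. Compound 3 is estimated at 3.7, with a range from 3 to 4.5, and most probably again only a limit in this assay.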

Compound 3, negative logarithm of the half-maximal effective concentration: < 4
Compound 3: a limit, no number; the forecaster's own chance of this, stated with the estimate: 70%; the middle value lies beyond the limit too.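

At this aromatic carbon, tert-butyl in place of methoxy gives a number at least 0.78 log units lower from compound 1 to compound 3 (beyond the scatter), so a second alkyl group falls short of methoxy, as ethyl did. The step between the ethyl and tert-butyl compounds cannot be read, as both values are limits and neither group can be ranked against the other. The alkyl compounds now share that limit: the limit of < 4 in this assay, at which 2 of the 3 values shown sit.

Still open, on these data alone, is whether an ethoxy or a longer alkoxy chain at this carbon would keep a readable number. The same holds for a hydroxyl, an amine or a chlorine there.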